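The source may hold more compounds than are shown below. What is called first, only, known or untested is meant among the compounds shown, and "the series" means these compounds.

Measured compounds:
- compound 1 `O=C(Nc1cccc(-n2cc(-c3ccncc3)c(-c3ccc(Cl)c(O)c3)n2)c1)Nc1ccc(Cl)c(Cl)c1` — > 32500 nM
- compound 2 `COc1cc(-c2nn(-c3cccc(NC(=O)c4ccc(Cl)c(C(F)(F)F)c4)c3)cc2-c2ccncc2)ccc1Cl` — > 32500 nM

In a functional assay on SK-OV-3 cells (Homo sapiens) for inhibition, read by sulforhodamine B assay, with a stated time of 48 h (on this read-out higher numbers stand for lower toxicity in this test and lower numbers for higher toxicity in this test), compound 1 gives > 32500 nM, which is a limit of the assay and not a number. In this assay compound 2 likewise gives > 32500 nM, again only a limit. Compound 2 therefore stands where every value shown stands, at the limit (the limit of > 32500 nM in this assay, at which 2 of the 2 values shown sit); nothing measured separates the two compounds.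

Compound 3 `COc1cc(-c2nn(-c3cccc(NC(=O)c4cccc(C(F)(F)F)c4)c3)cc2-c2ccncc2)ccc1Cl` has not yet been measured. It differs from compound 2 by hydrogen in place of chloro on an aromatic carbon. With both shown values sitting at a limit, no measured step of any size is available, and a change of one chlorine on the outer aryl amide gives no ground to expect a move beyond the scatter in this assay. Compound 3 is expected at 40000 nM, within 15000 nM to 100000 nM, an estimated step that the limit leaves unreadable from compound 2 to compound 3, most likely reported again only as a limit.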

Compound 3, concentration lethal to 50% of the cells: > 50000 nM
Compound 3: a limit, no number; the forecaster's own chance of this, stated with the estimate: 80%; at least 1.2-fold (0.09 log units) between middle value and limit.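

In this assay compound 3 gives > 50000 nM, a limit of the assay and not a number. Among the compounds shown here, compound 2 gives > 32500 nM, also only a limit, so no step to compound 3 can be read. Whether hydrogen in place of chloro shifts the read-out in this assay stays open: none of the compounds shown gives a number.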